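The compounds below may be only part of what the source reports. "The series", "measured", "known", "first", "only" and "open" are said of these compounds alone.

Measured so far:
compound 1 `O=C1NC(c2c[nH]nc2-c2ccccc2)Nc2c(I)cc(Cl)cc21` — "not determined" (no result reported)
compound 2 `Cc1cc(Cl)cc2c1NC(c1c[nH]nc1-c1ccccc1)NC2=O` — 5100 nM
compound 3 `O=c1[nH]c(-c2c[nH]nc2-c2ccccc2)nc2ccccc12` — "not determined" (no result reported)

In an assay on HEK293 cells for inhibition of transient receptor potential cation channel subfamily M member 2 (Homo sapiens), read by patch clamp, with a stated time of 60 s (a higher number here means a weaker inhibitor, a lower number a stronger inhibitor), compound 2 gives 5100 nM. Among the compounds with values here, for compound 1 the outcome in this assay is "not determined" (no result reported), and for compound 3 it is "not determined" (no result reported), so compound 2 carries the only number and stands alone; no comparison among measured compounds is possible.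

Compound 4 `Cc1cc(Br)cc2c1NC(c1c[nH]nc1-c1ccccc1)NC2=O` differs from compound 2 in one place: bromo in place of chloro on an aromatic carbon. Within the data shown here, no measured pair shows what such a swap does here. A change this small is expected to move this assay little, if at all, most likely within the usual scatter and in no certain direction. Compound 4 is therefore expected near 4000 nM, between 1500 nM and 12000 nM, a step of a 1.3-fold lower number from compound 2 to compound 4 (0.11 log units; within the scatter).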

Compound 4, half-maximal inhibitory concentration: 4600 nM
For compound 4 the middle estimate is 1.2-fold (0.06 log units) below the measured one; the range from low to high includes it.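

In this assay, bromo in place of chloro on this aromatic carbon, para to a fused ring, gives a 1.1-fold lower number from compound 2 to compound 4 (0.04 log units; within the scatter), so the two halogens cannot be told apart at this position. Until now, compound 2 offered a single number and no reading of any change here. Nothing available explains this result. On these data alone, whether a group other than a halogen, such as an amine, a methoxy group or a carboxylic acid, would fit at this position stays open. So does the effect of replacing the neighbouring methyl group with a longer chain such as ethyl.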